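Replacing a nitrophenyl with a methylphenyl on the urea nitrogen

This account rests on a few compounds, and the source may have more. Where it says the series, first, only, none or still open, it means among the compounds named here.

Compound 1 `O=C(Nc1ccc([N+](=O)[O-])cc1)N[C@H]1CC[C@H](Oc2ccc(F)cc2)CC1` gives 2300 nM in a functional assay on CRL2813 cells (Homo sapiens) for cytotoxicity, read by sulforhodamine B assay, with a stated time of 5 days; a lower number here means a stronger inhibitor, a higher number a weaker inhibitor.
Compound 2 `O=C(Nc1cccc(Br)c1)N[C@H]1CC[C@H](Oc2ccc(F)cc2)CC1` gives 6200 nM in this assay.
Compound 3 `O=C(Nc1cccc([N+](=O)[O-])c1)N[C@H]1CC[C@H](Oc2ccc(F)cc2)CC1` gives 6700 nM in this assay.

Compound 3 has the highest number of the three: the step of a 2.9-fold higher number from compound 1 to compound 3 (0.46 log units; beyond the scatter) is beyond the scatter, while the step of a 1.1-fold higher number from compound 2 to compound 3 (0.03 log units; within the scatter) is within it. Compound 4 `Cc1ccccc1NC(=O)N[C@H]1CC[C@H](Oc2ccc(F)cc2)CC1` differs from compound 3 by 2-methylphenyl in place of 3-nitrophenyl on an amide-type nitrogen. Within the data shown here, no measured step tests a methyl here; the closest guide is the swap of nitro for bromo at the same position, a 1.1-fold higher number from compound 2 to compound 3 (0.03 log units; within the scatter), which changed little. The step of a 1.0-fold lower number from compound 3 to compound 4 (0.01 log units; within the scatter) is therefore expected to stay within the scatter. Compound 4 is estimated at 6500 nM, in the range 2800 nM to 16000 nM.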

Compound 4, half-maximal inhibitory concentration: > 20000 nM
Compound 4: no number, only a limit; the forecaster's own chance of this, stated with the estimate: 10%; middle value at least 3.0-fold (0.48 log units) from the limit.
By their numbers in this assay, from the lowest: compound 1; then compounds 2 and 3 (each within the scatter of the next). At a limit, above all of these: compound 4.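

In this assay compound 4 gives no number, only a limit: the limit of > 20000 nM in this assay, at which 1 of the 4 values shown sits. The 2-methylphenyl group does clearly worse here than each other group shown, with an at least 2.9-fold higher number from compound 3 to compound 4 (0.47 log units; beyond the scatter), an at least 3.2-fold higher number from compound 2 to compound 4 (0.50 log units; beyond the scatter) and an at least 8.6-fold higher number from compound 1 to compound 4 (0.93 log units; beyond the scatter). Among these compounds, compound 4 is also the only one of the four without a nitro or bromo group on this ring, so the choice of group on this amide-type nitrogen can matter more than the earlier steps suggested.

Going from 3-nitrophenyl to 2-methylphenyl changes both the group and its place on the ring, and the compounds shown do not separate the two. Going by these compounds, how an amine or a methoxy group on that ring would read also stays open.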